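Replacing pyridin-2-yl in the series: compound 3 to compound 4

The source may hold more compounds than are shown below. What is called first, only, known or untested is meant among the compounds shown, and "the series" means these compounds.

In a functional assay on NB1 cells (Homo sapiens) for cytotoxicity, read by MTT assay, with a stated time of 3 days (on this read-out higher numbers stand for weaker inhibition and lower numbers for stronger inhibition), compound 1 (`N#Cc1c(Cl)nc(SCc2nc3ccccc3[nH]2)nc1-c1ccccc1`) gives 2.87 nM, compound 2 (`N#Cc1c(Nc2ccccc2)nc(SCc2nc3ccccc3[nH]2)nc1-c1ccccc1`) gives 2.5 nM and compound 3 (`N#Cc1c(Nc2ccccn2)nc(SCc2nc3ccccc3[nH]2)nc1-c1ccccc1`) gives 3.9 nM. Compound 3 therefore stands within the scatter of both other compounds, and these three values show no order.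

The next change, to compound 4 (`N#Cc1c(NNC(N)=S)nc(SCc2nc3ccccc3[nH]2)nc1-c1ccccc1`), falls on a nitrogen on an aromatic ring: a group of 4 heavy atoms (1 carbon, 2 nitrogen, 1 sulfur; no ring) in place of a group of 6 heavy atoms (5 carbon, 1 nitrogen; one six-membered aromatic ring with 1 hetero atom), on a nitrogen on an aromatic ring.

For the measured compounds named here, three measured steps bear on it. Replacing chloro with anilino gives a 1.1-fold lower number from compound 1 to compound 2 (0.06 log units; within the scatter), and replacing chloro with (pyridin-2-yl)amino gives a 1.4-fold higher number from compound 1 to compound 3 (0.13 log units; within the scatter). Changing the group on the nitrogen itself, pyridin-2-yl in place of phenyl, gives a 1.6-fold higher number from compound 2 to compound 3 (0.19 log units; within the scatter). All three lie within the scatter, so this position has so far tolerated each change made there. However, every measured group on that nitrogen carries a ring, so the open-chain group entering here has no direct precedent, and the range must stay wide.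

No step beyond the scatter is expected in this assay, and no direction is favoured. The estimate corresponds to a 1.2-fold lower number from compound 3 to compound 4 (0.09 log units; within the scatter), which is an expected step within the scatter. For compound 4 the estimated value is 3.2 nM, with an expected range from 1.1 nM to 10 nM.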

Compound 4, half-maximal inhibitory concentration: 5.81 nM
Compound 4: the middle estimate sits 1.8-fold (0.26 log units) below what was measured; the measured number falls inside the stated range.
By their numbers in this assay, from the lowest: compounds 2, 1, 3 and 4 (each within the scatter of the next, the first and the last beyond it).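

In this assay the step of a 1.5-fold higher number from compound 3 to compound 4 (0.17 log units; within the scatter) stays within the scatter, so on this nitrogen an open-chain group with no ring keeps the number level with that of the pyridin-2-yl group in compound 3. For the compounds shown here, the same group also gives the first steps that pass beyond the scatter, both modest: a 2.3-fold higher number from compound 2 to compound 4 (0.37 log units; beyond the scatter) and a 2.0-fold higher number from compound 1 to compound 4 (0.31 log units; beyond the scatter). Thus compound 4 separates from compound 1 and from compound 2 but not from compound 3, and the position is no longer flat across all compounds, though the shift remains small and no data at hand explain it.

The compounds shown leave open whether the sulfur or the open chain itself accounts for this modest separation, which a semicarbazide chain carrying oxygen in place of sulfur, or a plain hydrazine group on the same aromatic carbon, would help to settle. They also leave open whether a saturated ring such as morpholine on that aromatic carbon would fall with compound 2 or with compound 4.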